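The source may hold more compounds than are shown below. What is called first, only, known or untested is meant among the compounds shown, and "the series" means these compounds.

Working notes on the series. In a functional assay on A549 cells (Homo sapiens) for cytotoxicity, with a stated time of 48 h (on this read-out lower numbers stand for stronger inhibition and higher numbers for weaker inhibition), compound 1 `CC(C)COc1ccc2oc(/C=C/[S+](C)[O-])cc(=O)c2c1` gives 1100 nM, compound 2 `CCCCOc1ccc2oc(/C=C/[S+](C)[O-])cc(=O)c2c1` gives 1400 nM and compound 3 `CC(C)CCOc1ccc2oc(/C=C/[S+](C)[O-])cc(=O)c2c1` gives 1000 nM. Compound 3 stands level with the other two: a 1.1-fold lower number from compound 1 to compound 3 (0.04 log units; within the scatter) and a 1.4-fold lower number from compound 2 to compound 3 (0.15 log units; within the scatter) both lie within the scatter, as does a 1.3-fold higher number from compound 1 to compound 2 (0.10 log units; within the scatter). No order can be drawn among these three.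

The next compound, still unmeasured, is compound 4 `C[S+]([O-])/C=C/c1cc(=O)c2cc(C#N)ccc2o1`. The structural change is cyano in place of isopentyloxy on an aromatic carbon.

The measured steps bear on this only in part. They show that swapping one chain for another at this place moves this assay very little, with a 1.4-fold lower number from compound 2 to compound 3 (0.15 log units; within the scatter) the largest of them. For the measured compounds named here, none of them removes the chain or brings in cyano, so the size of this step has no direct precedent. A change of this kind goes well beyond those chain swaps, so a modest step towards a higher number is expected, with the direction uncertain. The expected step is a 2.0-fold higher number from compound 3 to compound 4 (0.30 log units; within the scatter). The estimate for compound 4 is 2000 nM, with an expected range from 500 nM to 8000 nM.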

Compound 4, half-maximal inhibitory concentration: > 10000 nM
Compound 4: a limit, no number (the forecaster's own chance of this, stated with the estimate: 10%); at least 5.0-fold (0.69 log units) between middle value and limit.
By their numbers in this assay, from the lowest: compounds 3, 1 and 2 (each within the scatter of the next). At a limit, above all of these: compound 4.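

In this assay compound 4 sits at a limit, > 10000 nM, which is a limit of the assay and not a number. The chain swaps all stayed within the scatter, but replacing the chain with cyano on this aromatic carbon gives steps beyond it, whichever chain leaves: an at least 10-fold higher number from compound 3 to compound 4 (1.00 log units; beyond the scatter) for isopentyloxy, an at least 7.1-fold higher number from compound 2 to compound 4 (0.85 log units; beyond the scatter) for butoxy and an at least 9.0-fold higher number from compound 1 to compound 4 (0.95 log units; beyond the scatter) for isobutoxy. This position therefore tolerates these three chains equally in this read-out but does not tolerate the change to cyano, and the true size of the change remains unknown, as each step gives only a minimum: the limit of > 10000 nM in this assay, at which 1 of the 4 values shown sits.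

The compounds shown cannot separate the loss of the chain from the arrival of cyano, and a plain hydrogen, a methoxy group or an amine on this aromatic carbon would bear on that question. They also leave open how short the chain can become before the number rises, and whether a longer chain, such as octyloxy, would stay level with compound 1, compound 2 and compound 3.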